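A few compounds are considered here, and "the series" means these few. Any claim that something is new, unique, unknown or untested is made for them only; others in the source may bear on it.

Measured compounds:
- compound 2, `O=C(Nc1ccc(Cl)c(-c2nc3ccccc3[nH]2)c1)c1ccc(F)cc1`: 251 nM
- compound 1, `CCOc1cc(C(=O)Nc2ccc(Cl)c(-c3nc4ccccc4s3)c2)cc(OCC)c1OCC`: "not active" (no number reported)
- compound 3, `CCOc1cc(C(=O)Nc2ccc(Cl)c(-c3cc4ccccc4[nH]3)c2)cc(OC)c1OC`: "not active" (no number reported)

For the measured compounds named here, in a functional assay on Shh Light II cells for inhibition of Sonic hedgehog protein (Mus musculus), read by reporter gene assay, with a stated time of 48 h, in the presence of a further agent that is not named here (on this read-out lower numbers stand for stronger inhibition and higher numbers for weaker inhibition), compound 2 gives 251 nM and is the only compound of the three for which a number was reported. Compound 1 is recorded as "not active" (no number reported) in this assay, with no number given. Compound 3 likewise is recorded as "not active" (no number reported) in this assay, again without a number. Going by the values given here, no step between two measured compounds with a single change is available, so the set gives no measured guide to the size of the change under discussion.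

Compound 4, `COc1ccc(C(=O)Nc2ccc(Cl)c(-c3nc4ccccc4[nH]3)c2)cc1`, has not yet been measured in this assay. It differs from compound 2 only in the change (methoxy in place of fluoro on an aromatic carbon). For compound 4 the step of a 1.2-fold higher number from compound 2 to compound 4 (0.08 log units; within the scatter) is expected to stay within the usual scatter, in either direction, since nothing in the shown values speaks for a larger shift. Compound 4 is therefore estimated at 300 nM, with a range from 100 nM to 900 nM.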

Compound 4, half-maximal inhibitory concentration: 117 nM
For compound 4 the middle estimate is 2.6-fold (0.41 log units) above the measured one; the measured number falls inside the stated range.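

In this assay, methoxy in place of fluoro on this aromatic carbon, para to a large group, gives a 2.1-fold lower number from compound 2 to compound 4 (0.33 log units; beyond the scatter), a modest step but one that goes beyond the scatter. For the compounds shown here, this is the first comparison in the set that isolates a single change, and it shows that the position accepts methoxy with no loss of inhibition and that the number moves toward stronger inhibition. Nothing measured here bears on why the number moves in this way.

From the compounds shown here alone, whether an ethoxy group, an amine or a carboxylic acid at the same position would move the number further in this direction remains open, since a single step cannot establish a trend. Compound 1 and compound 3 differ from compound 4 in more than one place, so they do not settle this question.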